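The source may hold more compounds than are shown below. What is called first, only, known or untested is meant among the compounds shown, and "the series" means these compounds.

Of the compounds shown here, three with a shared core have been tested in a toxicity assay on the whole organism (strain Icem-CET (SPF Caw)) for cytotoxicity, with Mus musculus as the target; a lower number here means that less compound is needed, a higher number that more compound is needed for the effect: compound 1, drawn as `C/C(C(=O)NC1CC1)=C(\C)c1ccc(Br)cc1`, compound 2, drawn as `C#CCNC(=O)/C(C)=C(\C)c1ccc(Br)cc1`, and compound 3, drawn as `C/C(C(=O)NC1CC1)=C(/C)c1ccc(Br)cc1`. Compound 1 gives 300 mg/kg and compound 2 gives 180 mg/kg. Compound 3 gives 100 mg/kg, the lowest of the three numbers. Its distance to compound 1 is the larger one: a 3.0-fold lower number from compound 1 to compound 3 (0.48 log units; beyond the scatter), a step that rests on (the fact that compounds 1 and 3 differ only in the configuration as drawn). Its distance to compound 2, a 1.8-fold lower number from compound 2 to compound 3 (0.26 log units; within the scatter), lies within the scatter, so compounds 2 and 3 cannot be told apart on these numbers.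

Compound 4, drawn as `C/C(C(=O)NC1CC1)=C(/C)c1ccc(F)cc1`, has not yet been measured. It differs from compound 3 in one place: fluoro in place of bromo on an aromatic carbon. Neither of the two measured steps touches this position. One concerns the drawn configuration of the double bond, the other the group on the amide nitrogen; the aromatic ring with its single substituent is the same in all three measured compounds. There is therefore no measured step that bears directly on the change from bromo to fluoro, and nothing in the numbers shown points in either direction.

On that basis the step of a 1.3-fold higher number from compound 3 to compound 4 (0.11 log units; within the scatter) is expected to stay within the scatter. Compound 4 is estimated at 130 mg/kg, with a range from 60 mg/kg to 280 mg/kg.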

Compound 4, dose for half-maximal effect: 110 mg/kg
For compound 4 the middle estimate is 1.2-fold (0.07 log units) above the measured one; measured number inside the range.
By their numbers in this assay, from the lowest: compounds 3, 4, 2 and 1 (each within the scatter of the next, the first and the last beyond it).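

Among these compounds, this is the first measured change on the aromatic ring, at the carbon para to a large group, and in this assay putting fluoro in place of bromo gives a 1.1-fold higher number from compound 3 to compound 4 (0.04 log units; within the scatter). Compounds 3 and 4 therefore cannot be told apart on these numbers: with the cyclopropyl group on the amide nitrogen and the double bond as drawn in compound 3 both kept, this one exchange of bromo for fluoro makes no difference that can be separated from the usual scatter of the measurement. No information at hand bears on why these two numbers lie so close together.

The compounds shown carry only bromo or fluoro at this position, so they leave open how an amine, a carboxylic acid or a longer chain would read in the same place. Fluoro also appears only together with the cyclopropyl group and the double bond as drawn in compound 3, so it remains open whether the same exchange would stay as small on compound 1 or compound 2.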